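The source may hold more compounds than are shown below. What is called first, only, known or untested is meant among the compounds shown, and "the series" means these compounds.

Two compounds in the series have numbers in an assay on C6 glioma cells for displacement of a labelled ligand from sodium- and chloride-dependent glycine transporter 1 (Rattus norvegicus), read by scintillation counting, with stated times of 30 min and 10 min; a higher number here means a weaker inhibitor, a lower number a stronger inhibitor. Compound 1 is `CCc1nnc(N2CCC(c3ccccc3)CC2)n1-c1ccccc1F`; in this assay compound 1 gives 3700 nM. Compound 2 is `CCc1nnc(-c2ccc(-c3ccccc3)cc2)n1-c1cccc(C)c1C`; in this assay compound 2 gives 940 nM. Compound 2 thus stands at the lower of the two numbers, and the gap from compound 1 to compound 2 lies beyond the usual scatter. Going by the values given here, the two structures differ in more than one place, so no single-point step connects them and nothing can be read from that gap about any one change.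

Compound 3 is `CCc1nnc(-c2ccc(-c3ccccc3)cc2)n1-c1cccc(Br)c1C` and has not been measured. It differs from compound 2 in one place: bromo in place of methyl on an aromatic carbon. Among the compounds with values here, no measured pair isolates this exchange, so there is no step on record to lean on, and the expectation rests on the single number of compound 2 alone. The expected step from compound 2 to compound 3 in this assay is a 1.3-fold lower number from compound 2 to compound 3 (0.13 log units; within the scatter), a small movement that need not reach beyond the scatter in either direction. Compound 3 is therefore expected to give about 700 nM in this assay, with a plausible range from 250 nM to 2000 nM.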

Compound 3, half-maximal inhibitory concentration: 2200 nM
Compound 3: middle estimate off by 3.1-fold (0.50 log units), on the low side; the measured number lies above the stated range.
By their numbers in this assay, from the lowest: compound 2; then compounds 3 and 1 (each within the scatter of the next).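

Working note: in this assay, placing bromo instead of methyl on this aromatic carbon, which is ortho to a methyl group and meta to a large group, gives a 2.3-fold higher number from compound 2 to compound 3 (0.37 log units; beyond the scatter), the first single-place step on record for the series. The position therefore does not accept this exchange without a change in the number, although the step is modest, and methyl is the better of the two groups seen here. Methyl and bromo match in the computed counts of heavy atoms, rings, hydrogen-bond donors and acceptors, and in net charge, so those counts do not separate them, and nothing measured in the series bears on the reason for the step.

The compounds shown leave open whether the higher number is particular to bromo or would also appear with chloro, methoxy or a plain hydrogen on this carbon. One pair also cannot show whether the same exchange would give a step of similar size with an amine or a carboxylic acid elsewhere on the shared core.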